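The compounds below may be only part of what the source reports. "The series", "measured", "known", "first", "only" and "open" are said of these compounds alone.

Compound 1 `CN(C)CCCNc1nc(-c2ccc(NC(=O)Nc3ccc(Cl)cc3Cl)cc2)nc2c(Cl)c(Cl)sc12` anchors this small set. In a functional assay on MDA-MB-231 cells (Homo sapiens) for cytotoxicity, read by MTT assay, with a stated time of 72 h (on this read-out lower numbers stand for stronger inhibition and higher numbers for weaker inhibition), compound 1 gives 3490 nM. Compound 2 `Cc1ccc(NC(=O)Nc2ccc(-c3nc(NCCCN(C)C)c4sc(Cl)c(Cl)c4n3)cc2)cc1` differs from it by 4-methylphenyl in place of 2,4-dichlorophenyl on an amide-type nitrogen; in this assay compound 2 gives 4980 nM, and the step is a 1.4-fold higher number from compound 1 to compound 2 (0.15 log units; within the scatter). Compound 3 `CCN(CC)CCCNc1nc(-c2ccc(NC(=O)Nc3ccc(Cl)cc3Cl)cc2)nc2c(Cl)c(Cl)sc12` carries the other variation, (diethylamino in place of dimethylamino on a saturated chain carbon, three bonds along the chain from a nitrogen on an aromatic ring); in this assay compound 3 gives 3940 nM, a step of a 1.1-fold higher number from compound 1 to compound 3 (0.05 log units; within the scatter). All three numbers sit within the usual scatter of one another, so no order among them can be claimed.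

Compound 4 `CCN(CC)CCCNc1nc(-c2ccc(NC(=O)Nc3ccc(C)cc3)cc2)nc2c(Cl)c(Cl)sc12` has not yet been measured. It differs from compound 3 by 4-methylphenyl in place of 2,4-dichlorophenyl on an amide-type nitrogen, the same change seen once already between compound 1 and compound 2, at the same place, here made on the core of compound 3 rather than that of compound 1. Resting on that single measured instance, which gave a 1.4-fold higher number from compound 1 to compound 2 (0.15 log units; within the scatter), a step of about a 1.4-fold higher number from compound 3 to compound 4 (0.14 log units; within the scatter) is expected in this assay, with only one prior example to lean on. Compound 4 is therefore estimated at 5500 nM, most likely between 2800 nM and 11000 nM.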

Compound 4, half-maximal inhibitory concentration: 3040 nM
Beside the measured number, compound 4's estimate is 1.8-fold (0.26 log units) above it; the range from low to high includes it.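

In this assay, putting 4-methylphenyl in place of 2,4-dichlorophenyl on the amide-type nitrogen gives a 1.3-fold lower number from compound 3 to compound 4 (0.11 log units; within the scatter), and this step does not differ measurably from the one seen on the core of compound 1: the same change on two cores in this assay, a 1.4-fold higher number (0.15 log units; within the scatter) from compound 1 to compound 2 and a 1.3-fold lower number (0.11 log units; within the scatter) from compound 3 to compound 4, 1.8-fold (0.27 log units) apart, within the scatter of two such steps

Diethylamino in place of dimethylamino gives a 1.6-fold lower number from compound 2 to compound 4 (0.21 log units; within the scatter), and this change likewise carries over without a measurable difference: the same change on two cores in this assay, a 1.1-fold higher number (0.05 log units; within the scatter) from compound 1 to compound 3 and a 1.6-fold lower number (0.21 log units; within the scatter) from compound 2 to compound 4, 1.8-fold (0.27 log units) apart, within the scatter of two such steps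

This shows that neither change behaves measurably differently on the two cores. Every step lies within the scatter, and the data do not show that either change moves the number at all, or that a step of a given size and direction carries over from one core to another.

The compounds shown leave open whether another group on the amide-type nitrogen, such as 4-methoxyphenyl or 4-trifluoromethylphenyl, would give a step beyond the scatter. They also leave open whether a morpholine in place of the dialkylamino group, or a longer chain, would do so.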